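The source may hold more compounds than are shown below. What is called first, only, known or untested is meant among the compounds shown, and "the series" means these compounds.

Compound 1, `CC(C)(C)NC(=O)N1CC1C#N`: > 300000 nM, which is a limit of the assay and not a number.
Compound 2, `CCOC(=O)c1ccc(NC(=O)N2CC2C#N)cc1`: 2300 nM.
Compound 3, `N#CC1CN1C(=O)Nc1ccc(Cl)cc1Cl`: 900 nM.

All three were tested in a functional assay on MCF7 cells (Homo sapiens) for inhibition; on this read-out higher numbers stand for weaker inhibition and lower numbers for stronger inhibition. Of the two compounds that gave a number, compound 2 stands highest, which here means the weaker of the two; compound 3 has the lower number, and the gap between them lies beyond the usual scatter of repeated measurements. Compound 1 gave only a limit, (the limit of > 300000 nM in this assay, at which 1 of the 3 values shown sits), so it offers no number to compare.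

Compound 4, `N#CC1CN1C(=O)Nc1ccc(S(N)(=O)=O)cc1`, has not yet been measured. It differs from compound 2 in a single place: sulfamoyl in place of ethoxycarbonyl on an aromatic carbon. The rest of the molecule is unchanged. Among the measured compounds shown here, no pair of measured compounds shows what such an exchange does in this assay, so neither direction can be read from the numbers at hand; one group with no net charge is swapped for another at the same position, and the shared core and the second substituent stay as they are. The step is therefore expected to stay within the scatter: a 1.1-fold higher number from compound 2 to compound 4 (0.04 log units; within the scatter). For compound 4 the estimate in this assay is 2500 nM, with a range from 800 nM to 8000 nM.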

Compound 4, half-maximal inhibitory concentration: > 15000 nM
Compound 4 ended at the assay's limit; the forecaster's own chance of this, stated with the estimate: 10%; middle value at least 6.0-fold (0.77 log units) away from the limit.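

In this assay, putting sulfamoyl in place of ethoxycarbonyl on this aromatic carbon, para to a group of 8 heavy atoms, gives an at least 6.5-fold higher number from compound 2 to compound 4 (0.81 log units; beyond the scatter), which means weaker inhibition and shows that this position is sensitive to the group placed on it. Among the compounds shown here, neither group carries a net charge, so this pair shows that inhibition at this position can weaken markedly with no change in net charge, something no earlier pair of compounds could show. Compound 4 gives a limit and not a number, so the step has a lower bound but no known full size: the limit of > 15000 nM in this assay, at which 1 of the 4 values shown sits.

The exchange changes several things at once, including the loss of a chain and the gain of a hydrogen-bond donor, and this one pair cannot separate what each contributes to the step. Going by these compounds, how a carboxylic acid, an amine or a longer chain such as butoxycarbonyl would behave at this position remains open, so it is not yet known whether ethoxycarbonyl is unusually well accepted here or sulfamoyl unusually poorly.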